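The source may hold more compounds than are shown below. What is called first, only, known or untested is meant among the compounds shown, and "the series" means these compounds.

Measured so far in a functional assay on NCI-N87 cells (Homo sapiens) for antiproliferative activity; on this read-out higher numbers stand for weaker inhibition and lower numbers for stronger inhibition:
- compound 1 `Cn1ncc2cc(Nc3ncnn4ccc(CN5CCC(N)CC5)c34)ccc21`: "not active" (no number reported)
- compound 2 `NC1CCN(Cc2ccn3ncnc(Nc4ccccc4)c23)CC1`: 140 nM
- compound 3 `Cc1ccccc1Nc1ncnn2ccc(CN3CCC(N)CC3)c12`: 3300 nM

Compound 3 stands highest of the two numbers in this assay, and compound 1 adds no number. The next compound is compound 4 `NC1CCN(Cc2ccn3ncnc(Nc4cccc(Cl)c4)c23)CC1`, which has 3-chlorophenyl in place of 2-methylphenyl on a nitrogen on an aromatic ring. Going by the values given here, the one measured step that bears on this is a 24-fold higher number from compound 2 to compound 3 (1.37 log units; beyond the scatter), which was large and beyond the scatter. It added the methyl that now leaves. Among the compounds with values here, no measured step covers the chlorine, so a return only part of the way is expected. The expected change, a large one towards a lower number, is estimated as a 13-fold lower number from compound 3 to compound 4 (1.12 log units; beyond the scatter). For compound 4 the estimate is 250 nM, with an expected range of 60 nM to 1000 nM.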

Compound 4, half-maximal inhibitory concentration: 60 nM
Estimate against measurement, compound 4: 4.2-fold (0.62 log units) above; the range from low to high includes it.
By their numbers in this assay, from the lowest: compound 4; then compound 2; then compound 3.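

In this assay the exchange of 2-methylphenyl for 3-chlorophenyl gives a 55-fold lower number from compound 3 to compound 4 (1.74 log units; beyond the scatter) and more than recovers the loss seen with the methyl. Chloro in place of hydrogen gives a 2.3-fold lower number from compound 2 to compound 4 (0.37 log units; beyond the scatter), so this aromatic ring can carry a substituent with a modest gain, whereas the methyl of compound 3 brought a large loss. No measured evidence explains this difference between the two substituents. Compound 3 and compound 4 differ in both group and ring position, so the chlorine and its placement remain unseparated. As far as these compounds go, a 3-methylphenyl or 2-chlorophenyl group would separate them, and a methoxy group or fluorine remains open here.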